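Trimming the Ester: From Compound 2 to Compound 3

The source may hold more compounds than are shown below. What is called first, only, known or untested is meant among the compounds shown, and "the series" means these compounds.

Compound 1 `CCOC(=O)[C@@H](N)CCC(=O)NCCSC(=O)C(C)(C)C` and compound 2 `CCCCOC(=O)[C@@H](N)CCC(=O)NCCSC(C)=O` were both tested in an ADME assay on isolated protein for metabolic stability, with Cocaine esterase (Homo sapiens) as the target; on this read-out lower numbers stand for a shorter-lived compound and higher numbers for a longer-lived compound. Compound 1 gives 0.167 h. Compound 2 gives 0.167 h, level with compound 1 within the scatter. Compound 3 `CCOC(=O)[C@@H](N)CCC(=O)NCCSC(C)=O` has not yet been measured. It differs from compound 2 by hydrogen in place of ethyl on a saturated chain carbon, two bonds along the chain from an oxygen next to a carbonyl group, the ethyl ester already present in compound 1. Since compound 1 and compound 2 sit at the same level, no step beyond the scatter is expected from compound 2 to compound 3, that is no change at the digits printed from compound 2 to compound 3 (within the scatter). Compound 3 is therefore estimated at 0.167 h, with a range from 0.08 h to 0.35 h.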

Compound 3, half-life: 0.167 h
Estimate against measurement, compound 3: no gap at the digits printed; low and high end bracket the measured number.
By their numbers in this assay, from the lowest: compounds 1, 2 and 3 (each within the scatter of the next).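

Compound 3 links the two earlier compounds, which differ in two places, so each change can now be read on its own. In this assay, butyl to ethyl on the ester gives no change at the digits printed from compound 2 to compound 3 (within the scatter), and methyl in place of tert-butyl on a carbonyl carbon gives no change at the digits printed from compound 1 to compound 3 (within the scatter). Nothing available explains why neither change moves the half-life.

Still open, from the compounds shown here alone, is whether a carboxylic acid in place of the ethyl ester would shift this read-out. The same question stands for a chain longer than butyl.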